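The compounds below may be only part of what the source reports. "The series", "measured", "known", "first", "only" and "open" are said of these compounds alone.

Compound 2, `CCN(CC)CCn1cnnc1-c1cc(Oc2ccc(NC(=O)Nc3cccc(C(F)(F)F)c3)cc2F)ccn1`, and compound 1, `CN(C)CCn1cnnc1-c1cc(Oc2ccc(NC(=O)Nc3ccccc3C(F)(F)F)cc2F)ccn1`, were both tested in a functional assay on HT-29 cells (Homo sapiens) for antiproliferative activity, read by MTT assay, with a stated time of 72 h; a higher number here means a weaker inhibitor, a lower number a stronger inhibitor. In this assay compound 2 gives 630 nM, while compound 1 gives 5860 nM. Among the compounds with values here, of the two numbers, the one for compound 2 is the lower, and its gap to compound 1 lies beyond the scatter. Within the data shown here, the two compounds differ in two places at once, in the amine-bearing chain on the shared core and in where the trifluoromethyl sits on the outer ring, so no single step between them can be drawn. Compound 3, `CCN(CC)CCn1cnnc1-c1cc(Oc2ccc(NC(=O)Nc3ccccc3C(F)(F)F)cc2F)ccn1`, keeps the chain of compound 2 and changes one thing: 2-(trifluoromethyl)phenyl in place of 3-(trifluoromethyl)phenyl on an amide-type nitrogen. Its trifluoromethyl-bearing ring is thus that of compound 1. Because compound 1 gives 5860 nM with this ring, a move toward the weaker side is expected for compound 3, though how much of the gap between compound 1 and compound 2 belongs to the ring and how much to the chain cannot be told from these two numbers. The step from compound 2 to compound 3 is expected to be a 4.0-fold higher number from compound 2 to compound 3 (0.60 log units; beyond the scatter). Compound 3 is estimated to give about 2500 nM, within a range of 800 nM to 8000 nM.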

Compound 3, half-maximal inhibitory concentration: 3410 nM
Estimate against measurement, compound 3: 1.4-fold (0.13 log units) below; low and high end bracket the measured number.
By their numbers in this assay, from the lowest: compound 2; then compounds 3 and 1 (each within the scatter of the next).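

In this assay, 2-(trifluoromethyl)phenyl in place of 3-(trifluoromethyl)phenyl on the amide-type nitrogen, with the diethylamino chain held fixed, gives a 5.4-fold higher number from compound 2 to compound 3 (0.73 log units; beyond the scatter), so this change alone, which keeps the same atoms, is enough to separate the two compounds beyond the scatter. With the 2-(trifluoromethyl)phenyl ring held fixed, diethylamino in place of dimethylamino gives a 1.7-fold lower number from compound 1 to compound 3 (0.24 log units; within the scatter), which lies within the scatter, so the gap that could not be divided earlier now reads as belonging to the ring change rather than to the chain, at least along this route. Nothing measured here speaks to why the place of the trifluoromethyl on this ring matters so much.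

As far as these compounds go, the chain step has been read only with the 2-(trifluoromethyl)phenyl ring, so whether dimethylamino and diethylamino also match with the 3-(trifluoromethyl)phenyl ring remains open. Also open, from the compounds shown here alone, is how the activity would respond to a nitrile in place of the trifluoromethyl, or to a longer chain between the amine and the shared core.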